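Moving the trifluoromethyl group on the aryl urea

The compounds below may be only part of what the source reports. "The series", "measured", "known", "first", "only" and "open" are said of these compounds alone.

Values in a functional assay on MCF7 cells (Homo sapiens) for inhibition, read by MTT assay, with a stated time of 72 h (on this read-out lower numbers stand for stronger inhibition and higher numbers for weaker inhibition), so far:
- compound 1 `COc1cc(NC(C)CCCNC(=O)Nc2cccc(F)c2)c2ncccc2c1` gives 18000 nM
- compound 2 `COc1cc(NC(C)CCCNC(=O)Nc2cc(C(F)(F)F)cc(C(F)(F)F)c2)c2ncccc2c1` gives 1600 nM
- compound 3 `COc1cc(NC(C)CCCNC(=O)Nc2ccc(C(F)(F)F)cc2)c2ncccc2c1` gives 1900 nM

Compound 3 at 1900 nM and compound 2 at 1600 nM lie within the scatter of each other, and compound 1 has by far the highest number of the three. Compound 4 `COc1cc(NC(C)CCCNC(=O)Nc2cccc(C(F)(F)F)c2)c2ncccc2c1` has 3-(trifluoromethyl)phenyl in place of 4-(trifluoromethyl)phenyl on an amide-type nitrogen, counted as 3-(trifluoromethyl)phenyl in place of 4-(trifluoromethyl)phenyl on an amide-type nitrogen and with the same atoms joined differently.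

Within the data shown here, only one measured step bears on this, the modest 9.5-fold lower number from compound 1 to compound 3 (0.98 log units; beyond the scatter) on going to 4-(trifluoromethyl)phenyl from 3-fluorophenyl. Among the measured compounds shown here, that step changes the group as well as its place, so no measured pair isolates the place alone. Compound 2, which also carries trifluoromethyl, shows 1600 nM and so gives no sign of a large shift. The expected change, a 1.3-fold higher number from compound 3 to compound 4 (0.12 log units; within the scatter) in this assay, is therefore none beyond the scatter. In this assay compound 4 is estimated at 2500 nM with an expected range from 1000 nM to 6500 nM as a working figure.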

Compound 4, half-maximal inhibitory concentration: 3300 nM
Beside the measured number, compound 4's estimate is 1.3-fold (0.12 log units) below it; measured number inside the range.
By their numbers in this assay, from the lowest: compounds 2, 3 and 4 (each within the scatter of the next, the first and the last beyond it); then compound 1.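

In this assay, the place change by itself gives a 1.7-fold higher number from compound 3 to compound 4 (0.24 log units; within the scatter), so 3-(trifluoromethyl)phenyl and 4-(trifluoromethyl)phenyl on the amide-type nitrogen are not told apart. Taking one trifluoromethyl off the bis-substituted ring gives a 2.1-fold higher number from compound 2 to compound 4 (0.31 log units; beyond the scatter), a modest step that separates compound 2 from compound 4 even though compound 3 lies within the scatter of both. With the place held, trifluoromethyl in place of fluoro gives a 5.5-fold lower number from compound 1 to compound 4 (0.74 log units; beyond the scatter), so among these compounds the identity of the group moves the number, while its place, as far as the scatter allows, does not.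

No measurement shown offers an explanation for any of these steps. Still open, going by these compounds, is whether a nitrile or a carboxylic acid in place of trifluoromethyl on this aromatic carbon would hold or lose the values seen in this assay for this series.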